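The compounds below may be only part of what the source reports. "The series", "measured", "known", "first", "only" and "open" are said of these compounds alone.

Measured compounds:
compound 1, `NC(=O)c1cccc(-c2cc(C(O)(C(F)(F)F)C(F)(F)F)cnc2N2CCN(S(=O)(=O)c3ccc(N)nc3)CC2)c1` — 17 mL.min-1.g-1
compound 2, `Nc1ccc(S(=O)(=O)N2CCN(c3ncc(C(O)(C(F)(F)F)C(F)(F)F)cc3-c3cncc(F)c3)CC2)cn1` — 24 mL.min-1.g-1

In an ADME assay (liver) for metabolic stability, with Liver microsome (Homo sapiens) as the target, using microsomes and NADPH, with a stated time of 30 min, tested at 1 uM (on this read-out higher numbers stand for fast clearance and lower numbers for slow clearance), compound 2 gives 24 mL.min-1.g-1, the highest of the two numbers, with compound 1 nearest. Going by the values given here, the one measured step, a 1.4-fold higher number from compound 1 to compound 2 (0.15 log units; within the scatter), stays within the scatter. Compound 3, `Nc1ccc(S(=O)(=O)N2CCN(c3ncc(C(O)(C(F)(F)F)C(F)(F)F)cc3-c3cc4ccccc4[nH]3)CC2)cn1`, differs from compound 2 by 1H-indol-2-yl in place of 5-fluoropyridin-3-yl on an aromatic carbon. Among the compounds with values here, no measured step involves this replacement, so the only comparable change, a 1.4-fold higher number from compound 1 to compound 2 (0.15 log units; within the scatter), offers weak guidance. A step of a 1.5-fold higher number from compound 2 to compound 3 (0.16 log units; within the scatter) is expected, roughly toward faster clearance but uncertain. For compound 3 in this assay the estimate is 35 mL.min-1.g-1, within a range of 12 mL.min-1.g-1 to 100 mL.min-1.g-1.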

Compound 3, intrinsic clearance in microsomes: < 14 mL.min-1.g-1
Compound 3: no number, only a limit; the forecaster's own chance of this, stated with the estimate: 5%; at least 2.5-fold (0.39 log units) between middle value and limit.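

In this assay, compound 3 gives only a limit of the assay, not a number: the limit of < 14 mL.min-1.g-1 in this assay, at which 1 of the 3 values shown sits. Placing 1H-indol-2-yl on this aromatic carbon gives an at least 1.7-fold lower number from compound 2 to compound 3 (0.23 log units; that floor lies within the scatter), and the change from 3-carbamoylphenyl gives an at least 1.2-fold lower number from compound 1 to compound 3 (0.08 log units; that floor lies within the scatter). So this group, with more heavy atoms than 5-fluoropyridin-3-yl and a hydrogen-bond donor, does not push the clearance number up here, though neither floor clears the scatter. From the compounds shown here alone, the true size of both steps remains open, since compound 3 has no exact number. Also open, going by these compounds, is how a small amine or a carboxylic acid at this position would read.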